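This account rests on a few compounds, and the source may have more. Where it says the series, first, only, none or still open, it means among the compounds named here.

Measured in a functional assay on A549 cells (Homo sapiens) for inhibition, read by MTT assay, with a stated time of 72 h; a higher number here means a weaker inhibitor, a lower number a stronger inhibitor:
Compound 1 `Cc1ccc(CN2CCc3ncn(COCc4ccccc4)c3/C(=C/c3ccccc3)C2=O)cc1`: 11400 nM
Compound 2 `Cc1cccc(CN2CCc3ncn(COCc4ccccc4)c3/C(=C/c3ccccc3)C2=O)c1`: 16100 nM
Compound 3 `O=C1/C(=C\c2ccccc2)c2c(ncn2COCc2ccccc2)CCN1Cc1ccc(Cl)cc1`: 11800 nM

Compound 3 stands at 11800 nM, within the scatter of the other two compounds. Compound 4 `COc1ccc(CN2CCc3ncn(COCc4ccccc4)c3/C(=C/c3ccccc3)C2=O)cc1` has not yet been measured. It carries methoxy in place of chloro on an aromatic carbon, para to a large group. Among the compounds with values here, three measured steps bear on this change, all on the same aromatic ring: a 1.0-fold higher number from compound 1 to compound 3 (0.01 log units; within the scatter), a 1.4-fold lower number from compound 2 to compound 3 (0.13 log units; within the scatter) and a 1.4-fold higher number from compound 1 to compound 2 (0.15 log units; within the scatter). None of them leaves the scatter, although none introduces methoxy. No step beyond the scatter is therefore expected in this assay. The expected size of the change is a 1.1-fold higher number from compound 3 to compound 4 (0.03 log units; within the scatter). Compound 4 is estimated at 12500 nM, with an expected range of 7000 nM to 22000 nM.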

Compound 4, half-maximal inhibitory concentration: 46800 nM
Compound 4: middle estimate off by 3.7-fold (0.57 log units), on the low side; the measured number lies above the stated range.
By their numbers in this assay, from the lowest: compounds 1, 3 and 2 (each within the scatter of the next); then compound 4.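

In this assay, within the data shown here, the 4-methoxybenzyl group is the first change on this ring to leave the scatter, setting compound 4 apart from each earlier compound (a 4.0-fold higher number from compound 3 to compound 4 (0.60 log units; beyond the scatter)), (a 4.1-fold higher number from compound 1 to compound 4 (0.61 log units; beyond the scatter)) and (a 2.9-fold higher number from compound 2 to compound 4 (0.46 log units; beyond the scatter)). Chloro and methyl read alike on this aromatic carbon, para to a large group, whereas methoxy there gives a weaker inhibitor than either. Nothing measured here accounts for this difference. As far as these compounds go, whether a hydroxy, an ethoxy or an amine at this place would read like methoxy or like chloro remains open. So does whether methoxy elsewhere on this ring would give the same step.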